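A few compounds are considered here, and "the series" means these few. Any claim that something is new, unique, unknown or untested is made for them only; others in the source may bear on it.

Measured compounds in a functional assay on the whole organism (strain Kunming) with Mus musculus as the target, in the maximal electroshock model, with a stated time of 0.5 h; a lower number here means that less compound is needed, a higher number that more compound is needed for the effect:
compound 1 `O=C1NC2(CC2c2ccc3cccc(OCc4ccccc4)c3n2)C(=O)N1c1ccc(C(F)(F)F)cc1`: 300 mg/kg
compound 2 `O=C1NC2(CC2c2ccc3cccc(OCc4ccccc4)c3n2)C(=O)N1c1ccc(Cl)cc1`: 300 mg/kg
compound 3 `O=C1NC(=O)C2(CC2c2ccc3cccc(OCc4ccccc4)c3n2)N1`: 300 mg/kg

Compound 3 stands level with compound 1 and compound 2 at the digits shown, all three within the scatter of each other; no ordering among them can be read off.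

Compound 4 `Cc1ccc(N2C(=O)NC3(CC3c3ccc4cccc(OCc5ccccc5)c4n3)C2=O)cc1` differs from compound 3 by 4-methylphenyl in place of hydrogen on an amide-type nitrogen in a ring. For the measured compounds named here, the steps that bear on this change are no change at the digits printed from compound 1 to compound 3 (within the scatter) and no change at the digits printed from compound 2 to compound 3 (within the scatter), both of which exchange an aryl group on that ring nitrogen for hydrogen with no change beyond the scatter. Adding a further aryl group at the same site is therefore expected to give no step beyond the scatter in this assay, i.e. no change at the digits printed from compound 3 to compound 4 (within the scatter). Compound 4 is estimated at 300 mg/kg, within 150 mg/kg to 600 mg/kg.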

Compound 4, minimum effective dose: 100 mg/kg
Estimate against measurement, compound 4: 3.0-fold (0.48 log units) above; the measured number lies below the stated range.
By their numbers in this assay, from the lowest: compound 4; then compounds 1, 2 and 3 (each within the scatter of the next).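

In this assay the substituent on the aryl group at the amide-type ring nitrogen now matters: 4-methylphenyl in place of hydrogen gives a 3.0-fold lower number from compound 3 to compound 4 (0.48 log units; beyond the scatter) whereas the 4-chlorophenyl and 4-(trifluoromethyl)phenyl groups stayed level with hydrogen. Methyl on the aromatic carbon gives a 3.0-fold lower number from compound 2 to compound 4 (0.48 log units; beyond the scatter) in place of chloro and a 3.0-fold lower number from compound 1 to compound 4 (0.48 log units; beyond the scatter) in place of trifluoromethyl so an aryl group at this nitrogen does not by itself set the result. Nothing measured here accounts for this difference.

As far as these compounds go, whether ethyl or methoxy on that aromatic carbon, or an unsubstituted phenyl on the nitrogen, matches compound 4 stays open.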